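This account rests on a few compounds, and the source may have more. Where it says the series, first, only, none or still open, it means among the compounds named here.

Compounds measured:
Compound 1 `Cc1cc(C(N)=O)nn1Cc1cc(Cl)ccc1OCc1ccccc1` gives 3.7 in a physicochemical assay for lipophilicity, at pH 7.4; on this read-out lower numbers stand for lower lipophilicity and higher numbers for higher lipophilicity.
Compound 2 `CNC(=O)c1cc(C)n(Cc2cc(Cl)ccc2OCc2ccccc2)n1` gives > 3.7 in this assay, a limit of the assay rather than a number.
Compound 3 `Cc1cc(C(=O)NC(C)C)nn1Cc1cc(Cl)ccc1OCc1ccccc1` gives > 3.7 in this assay, likewise a limit and not a number.

Compound 3 thus stands at the upper edge of what this assay reports; of the values shown, (the limit of > 3.7 in this assay, at which 2 of the 3 values shown sit). Compound 4 `Cc1cc(C(=O)Nc2ccccc2)nn1Cc1cc(Cl)ccc1OCc1ccccc1` differs from compound 3 in one place: phenyl in place of isopropyl on an amide-type nitrogen. The measured steps that bear on this position are a number no lower from compound 1 to compound 3 (the limit leaves the size open) and a step that the two limits leave unreadable from compound 2 to compound 3; neither has a readable size. Among the compounds with values here, the amide nitrogen so far carries hydrogen, methyl and isopropyl only, so the step to phenyl has no direct precedent. Compound 4 is expected to sit at or beyond the limit as well, with an expected step that the limit leaves unreadable from compound 3 to compound 4 that would most likely again be reported only as a limit. The estimate for compound 4 is 4.3, between 3.7 and 5.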

Compound 4, distribution coefficient: > 3.7
Compound 4 was reported as a limit; the forecaster's own chance of this, stated with the estimate: 85%; the middle value lies beyond the limit too.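

In this assay compound 4 gives > 3.7, a limit of the assay and not a number. With phenyl, the first ring on the amide-type nitrogen, the step reads a number no lower from compound 1 to compound 4 (the limit leaves the size open). An aromatic ring at this place ends at the same limit as methyl and isopropyl: the limit of > 3.7 in this assay, at which 3 of the 4 values shown sit.

Going by these compounds, the steps among compound 2, compound 3 and compound 4 cannot be read, so their order remains open. Also open, on these data alone, is whether an amine or a carboxylic acid on the group at the amide-type nitrogen would bring the read-out back to a number.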